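The compounds below may be only part of what the source reports. "The series", "measured", "known", "first", "only" and "open" are said of these compounds alone.

Working notes on the series. In an assay on isolated protein for inhibition of Amine oxidase [flavin-containing] B (Homo sapiens), read by fluorescence (on this read-out higher numbers stand for weaker inhibition and lower numbers for stronger inhibition), the two measured compounds sit close together. Compound 1 `CC(=O)N1N=C(c2cc(O)c(O)c([N+](=O)[O-])c2)CC1c1nccs1` gives 68200 nM. Compound 2 `CC(=O)N1N=C(c2cc(O)c(O)c([N+](=O)[O-])c2)CC1c1ccc(C#N)cc1` gives 83200 nM; this is the higher of the two numbers, with compound 1 as its nearest neighbour, and the two lie within the scatter of each other. Among the measured compounds shown here, the single measured step, a 1.2-fold higher number from compound 1 to compound 2 (0.09 log units; within the scatter), exchanges 1,3-thiazol-2-yl for 4-cyanophenyl on the saturated ring carbon and does not move the number beyond the scatter.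

Compound 3 `CC(=O)N1N=C(c2cc(O)c(O)c([N+](=O)[O-])c2)CC1c1cccc(O)c1` is the next member, not yet measured in this assay. Relative to compound 2 the change is 3-hydroxyphenyl in place of 4-cyanophenyl on a saturated ring carbon. For the measured compounds named here, no measured step exchanges one group on the saturated ring carbon of this shared core for another of the same ring type, so the only step that bears on it is a 1.2-fold higher number from compound 1 to compound 2 (0.09 log units; within the scatter), which stayed within the scatter. The expected step in this assay is therefore a 1.1-fold lower number from compound 2 to compound 3 (0.05 log units; within the scatter), no more than the scatter in either direction. Compound 3 is estimated at 75000 nM, with a range from 25000 nM to 220000 nM.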

Compound 3, half-maximal inhibitory concentration: 85200 nM
Compound 3: middle estimate off by 1.1-fold (0.06 log units), on the low side, and the stated range covers the measured number.
By their numbers in this assay, from the lowest: compounds 1, 2 and 3 (each within the scatter of the next).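

In this assay, the exchange of 4-cyanophenyl for 3-hydroxyphenyl gives a 1.0-fold higher number from compound 2 to compound 3 (0.01 log units; within the scatter), and the exchange of 1,3-thiazol-2-yl for 3-hydroxyphenyl gives a 1.2-fold higher number from compound 1 to compound 3 (0.10 log units; within the scatter). Among the compounds shown here, the three groups on the saturated ring carbon therefore cannot be told apart on this read-out, and this now holds for a second six-membered carbon ring with a different substituent, not only for the one pair seen before. The hydrogen-bond donor that enters with 3-hydroxyphenyl and the triple bond that leaves with 4-cyanophenyl come with no change beyond the scatter, and nothing at hand bears on why these numbers stay together.

Still open, going by these compounds, is whether any group at this position moves the number beyond the scatter, for example a primary amine, a carboxylic acid, a longer alkyl chain or a saturated ring such as cyclohexyl. Also open is whether the flatness seen here holds on a core with the acetyl group or the nitro group replaced, as every compound shown carries both.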